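The source may hold more compounds than are shown below. What is called first, only, known or untested is meant among the compounds shown, and "the series" means these compounds.

In a functional assay on HCT-116 cells (Homo sapiens) for antiproliferative activity, read by MTT assay, with a stated time of 72 h (a higher number here means a weaker inhibitor, a lower number a stronger inhibitor), the three measured compounds stand as follows:

compound 1, `NC1=NC2(CCSCC2)N(OCCCOc2cccc(Cl)c2)C(N)=N1`: 1 nM
compound 2, `NC1=NC2(CCSCC2)N(OCCCOc2cccc(Cl)c2Cl)C(N)=N1`: 1 nM
compound 3, `NC1=NC2(CCSCC2)N(OCCCOc2ccc(Cl)cc2)C(N)=N1`: 10 nM

Compound 3 holds the highest number of the three. Its nearest neighbour is compound 1, with a 10-fold higher number from compound 1 to compound 3 (1.00 log units; beyond the scatter), and the furthest is compound 2, with a 10-fold higher number from compound 2 to compound 3 (1.00 log units; beyond the scatter). Between the two lower compounds the step is no change at the digits printed from compound 1 to compound 2 (within the scatter).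

The account now turns to compound 4, `NC1=NC2(CCSCC2)N(OCCCOc2ccc(Br)cc2)C(N)=N1`, which has not yet been tested. It differs from compound 3 by bromo in place of chloro on an aromatic carbon. Among the measured compounds shown here, none of the measured steps exchanges one halogen for another: the two steps that lead to compound 3 alter the pattern of chloro substitution on the phenyl ring, and both are of modest size. For the measured compounds named here, no measured pair bears directly on the exchange of chloro for bromo, so the expectation rests on the close likeness of the group that leaves and the group that enters. Compound 4 is expected to give 10 nM, between 3 nM and 30 nM, which corresponds to an expected no change at the digits printed from compound 3 to compound 4 (within the scatter).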

Compound 4, half-maximal inhibitory concentration: 20 nM
Estimate against measurement, compound 4: 2.0-fold (0.30 log units) below; low and high end bracket the measured number.
By their numbers in this assay, from the lowest: compounds 1 and 2 (each within the scatter of the next); then compounds 3 and 4 (each within the scatter of the next).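

In this assay the exchange of chloro for bromo on an aromatic carbon para to a large group gives a 2.0-fold higher number from compound 3 to compound 4 (0.30 log units; within the scatter) and is the only halogen exchange among these compounds, so at this position the two halogens are not told apart. The larger gaps remain with the substitution pattern: the 4-bromophenyl compound shows a 20-fold higher number from compound 2 to compound 4 (1.30 log units; beyond the scatter) and a 20-fold higher number from compound 1 to compound 4 (1.30 log units; beyond the scatter) and thus stands with compound 3, apart from compounds 1 and 2. No measurement offered here accounts for these numbers.

As far as these compounds go, whether fluoro, iodo, methyl or a nitrile in the same place would read like chloro and bromo remains open. So does whether bromo would match chloro on the phenyl ring of compound 1, where the chloro sits elsewhere.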